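The source may report more compounds than this note shows. Statements on the series, on what has been measured and on what is new or still open speak of the compounds shown alone.

Compound 1, `CC(C)=CC(=O)Nc1cccc(Oc2nc(Nc3ccn(C)n3)nc3c2CSCC3)c1`, gives 44200 nM in a functional assay on A549 cells (Homo sapiens) for antiproliferative activity, read by MTT assay, with a stated time of 72 h; a lower number here means a stronger inhibitor, a higher number a weaker inhibitor. Compound 2, `CC(C)/C=C/C(=O)Nc1cccc(Oc2nc(Nc3ccn(C)n3)nc3c2CSCC3)c1`, gives 33500 nM. Compound 3, `COc1cccc(Nc2nc3c(c(Oc4cccc(NC(=O)C=C(C)C)c4)n2)CSCC3)c1`, gives 19800 nM.

Compound 4, `COc1cccc(Nc2nc3c(c(Oc4cccc(NC(=O)/C=C/C(C)C)c4)n2)CSCC3)c1`, has not yet been measured in this assay. It differs from compound 3 by 3-methylbut-1-en-1-yl in place of 2-methylprop-1-en-1-yl on a carbonyl carbon. The same change, at the same place, separates compound 1 from compound 2, namely (3-methylbut-1-en-1-yl in place of 2-methylprop-1-en-1-yl on a carbonyl carbon), and there it produced a 1.3-fold lower number from compound 1 to compound 2 (0.12 log units; within the scatter). The two cores differ by 3-methoxyphenyl in place of 1-methyl-1H-pyrazol-3-yl on a nitrogen on an aromatic ring, a change that gave a 2.2-fold lower number from compound 1 to compound 3 (0.35 log units; beyond the scatter). With the place of the change identical in both pairs, a step of similar size is expected for compound 4, a 1.2-fold lower number from compound 3 to compound 4 (0.09 log units; within the scatter), because a 1.3-fold lower number from compound 1 to compound 2 (0.12 log units; within the scatter) stayed small. Compound 4 is therefore estimated at 16000 nM. For compound 4 the expected range runs from 8000 nM to 32000 nM.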

Compound 4, half-maximal inhibitory concentration: 25300 nM
Beside the measured number, compound 4's estimate is 1.6-fold (0.20 log units) below it; the measured number falls inside the stated range.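

In this assay, 3-methylbut-1-en-1-yl in place of 2-methylprop-1-en-1-yl gives a 1.3-fold higher number from compound 3 to compound 4 (0.11 log units; within the scatter), and this agrees with the same change on the other core: the same change on two cores in this assay, a 1.3-fold lower number (0.12 log units; within the scatter) from compound 1 to compound 2 and a 1.3-fold higher number (0.11 log units; within the scatter) from compound 3 to compound 4, 1.7-fold (0.23 log units) apart, within the scatter of two such steps

3-Methoxyphenyl in place of 1-methyl-1H-pyrazol-3-yl gives a 1.3-fold lower number from compound 2 to compound 4 (0.12 log units; within the scatter), which also agrees with its earlier step: the same change on two cores in this assay, a 2.2-fold lower number (0.35 log units; beyond the scatter) from compound 1 to compound 3 and a 1.3-fold lower number (0.12 log units; within the scatter) from compound 2 to compound 4, 1.7-fold (0.23 log units) apart, within the scatter of two such steps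

So both changes carry over between these two cores within the scatter, but the chain steps are too small to show that the chain change has any effect of its own, and a single pair of cores sets no rule for the series.

The compounds shown leave open how a longer chain on the carbonyl carbon would behave. They also leave open whether an amine at the end of that chain would alter the number.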